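Working notes: chain extension from compound 2 to compound 3

A few compounds are considered here, and "the series" means these few. Any claim that something is new, unique, unknown or untested is made for them only; others in the source may bear on it.

Measured so far in a functional assay on PBMC cells (Homo sapiens) for inhibition, read by thymidine incorporation, with a stated time of 72 h; on this read-out lower numbers stand for stronger inhibition and higher numbers for weaker inhibition:
- compound 1, `CC1(C)CC(=O)C=C(Nc2ccc(Cl)cc2Cl)C1`: 17.6 ug/mL
- compound 2, `CCCCSC(=S)C1=C(Nc2ccc(Cl)cc2Cl)CC(C)(C)CC1=O`: compound 2 reports only a limit, > 50 ug/mL

Compound 2 stands at the limit of > 50 ug/mL in this assay, at which 1 of the 2 values shown sits; it gives no number, only that limit. Among the measured compounds shown here, the one measured step, an at least 2.8-fold higher number from compound 1 to compound 2 (0.45 log units; beyond the scatter), concerns a substituent on a double-bonded ring carbon of the shared core and ends in the limit of compound 2.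

Compound 3, `CCCCCCCCCCCSC(=S)C1=C(Nc2ccc(Cl)cc2Cl)CC(C)(C)CC1=O`, is not yet measured. Its difference from compound 2 is heptyl in place of hydrogen on a saturated chain carbon, four bonds along the chain from a sulfur; the rest of the structure is unchanged. No measured step concerns this saturated chain, so nothing shown bears directly on it. For the measured compounds named here, the only guide is that compound 2 already sits at the limit, so this assay gives no number from which a step could be counted in either direction. Compound 3 is therefore expected to sit near or beyond the same limit, with an expected step that the limit leaves unreadable from compound 2 to compound 3 from compound 2 and no direction to claim beyond the scatter. The estimate for compound 3 in this assay is 60 ug/mL, with a range from 25 ug/mL to 150 ug/mL, and it is likely that only a limit is reported again.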

Compound 3, half-maximal inhibitory concentration: > 50 ug/mL
Compound 3 gave a limit, no number; the forecaster's own chance of this, stated with the estimate: 70%; the middle value does not contradict the limit.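

In this assay compound 2 gives > 50 ug/mL as a limit, not a number. Compound 3 gives > 50 ug/mL as a limit too, so no step can be read from compound 2 to compound 3. Both stand at the same limit: the limit of > 50 ug/mL in this assay, at which 2 of the 3 values shown sit.

Left open is whether heptyl in place of hydrogen on the saturated chain changes inhibition at all.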